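A few compounds are considered here, and "the series" means these few. Any claim that something is new, unique, unknown or untested is made for them only; others in the source may bear on it.

Measured compounds in an in vitro functional assay on cells for agonist activity at Bombesin receptor subtype-3 (Mus musculus), read by luminescence and calcium flux; a lower number here means that less compound is needed, a higher number that more compound is needed for the effect:
- compound 1 `O=C(O)c1ccccc1-c1ccc(CCc2ncc(Cc3cccc(F)c3)[nH]2)cc1` gives 7.9 nM
- compound 2 `CCCCc1cnc(C(CC)Cc2ccc(-c3ccccc3C(=O)O)cc2)[nH]1` gives 340 nM
- compound 3 `CCCCc1cnc(/C=C/c2ccc(-c3ccccc3C(=O)O)cc2)[nH]1` gives 10000 nM

Of the three, compound 1 gives the lowest number in this assay. Its gap to compound 2 is beyond the usual scatter, and its gap to compound 3 is wider still, so compound 1 stands clearly apart from both as the most potent member of this small set. For the measured compounds named here, the shared core carries the biphenyl carboxylic acid and the imidazole; compound 1 differs from compounds 2 and 3 in what sits at the imidazole and in the linker, and no single-change step between any two measured compounds is available.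

Compound 4 `O=C(O)c1ccccc1-c1ccc(CCc2ncc(Cc3cccc(Cl)c3)[nH]2)cc1` is not yet measured. It differs from compound 1 in one place: chloro in place of fluoro on an aromatic carbon. Going by the values given here, no measured pair isolates a halogen swap of this kind, so the step is estimated, not read from the data. For a fluoro to chloro exchange on a 3-benzyl substituent, no change beyond the scatter in either direction is expected, with a slight lean toward a similar or marginally lower number.

For compound 4 the expected step in this assay from compound 1 is a 1.1-fold lower number from compound 1 to compound 4 (0.05 log units; within the scatter). Compound 4 is thus estimated at 7 nM, with a range of 2.5 nM to 22 nM.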

Compound 4, half-maximal effective concentration: 31 nM
For compound 4 the middle estimate is 4.4-fold (0.65 log units) below the measured one, and the stated range ends below it.
By their numbers in this assay, from the lowest: compound 1; then compound 4; then compound 2; then compound 3.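

In this assay, for the compounds shown here, the exchange of 3-fluorobenzyl for 3-chlorobenzyl gives a 3.9-fold higher number from compound 1 to compound 4 (0.59 log units; beyond the scatter) as the only single-change step so far. This modest step shows that the number responds to which halogen sits on this aromatic carbon, with fluoro giving the lower number of the pair. No measurement shown accounts for the step.

From the compounds shown here alone, it remains open how a bromo, methoxy or trifluoromethyl group would read in the same place, and whether a ring without any substituent would read higher or lower than either halogen. Also open, going by these compounds, is whether the halogen step keeps its size and direction when the linker of compound 1 is replaced by that of compound 2 or compound 3.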